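A few compounds are considered here, and "the series" means these few. Any claim that something is new, unique, unknown or untested is made for them only; others in the source may bear on it.

Measured so far:
Compound 1 `CCCCCCCCCCCC[C@@H](O)[C@H]1CC[C@H]([C@H](O)CCCCCCCCCCNC(=O)c2cccs2)O1`: 3390 nM
Compound 2 `CCCCCCCCCCCC[C@@H](O)[C@H]1CC[C@H]([C@H](O)CCCCCCCCCCNC(=O)c2ccco2)O1`: 100000 nM

In a functional assay on SNB-75 cells (Homo sapiens) for inhibition, read by colorimetric assay and sulforhodamine B assay, with a stated time of 48 h (a higher number here means a weaker inhibitor of growth, a lower number a stronger inhibitor of growth), compound 1 gives 3390 nM, the lower of the two numbers, which makes it the stronger growth inhibitor of this pair. Going by the values given here, its only measured neighbour is compound 2, and the step between them, a 29-fold higher number from compound 1 to compound 2 (1.47 log units; beyond the scatter), is large. That step put furan-2-yl in place of thiophen-2-yl on a carbonyl carbon, so it shows that a swap at this place can move the number a long way.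

The next compound is compound 3 `CCCCCCCCCCCC[C@@H](O)[C@H]1CC[C@H]([C@H](O)CCCCCCCCCCNC(=O)c2ccsc2)O1`, which has the same atoms as compound 1, joined differently: thiophen-3-yl in place of thiophen-2-yl on a carbonyl carbon. Here thiophen-3-yl takes the place of thiophen-2-yl, so the ring remains a thiophene. Among the compounds with values here, no measured step tests this kind of change, and the single furan step bears on it only loosely. The expected result in this assay is therefore no change beyond the scatter, with more room on the weaker side.

The estimated step is a 1.0-fold higher number from compound 1 to compound 3 (0.01 log units; within the scatter).

For compound 3 the expected value is 3500 nM, with an estimated range of 700 nM to 25000 nM.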

Compound 3, concentration for 50% growth inhibition: 2820 nM
The estimate for compound 3 lay 1.2-fold (0.09 log units) above the measured number; measured number inside the range.
By their numbers in this assay, from the lowest: compounds 3 and 1 (each within the scatter of the next); then compound 2.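

In this assay, thiophen-3-yl in place of thiophen-2-yl on a carbonyl carbon gives a 1.2-fold lower number from compound 1 to compound 3 (0.08 log units; within the scatter), so within these compounds the choice between the two thiophene forms makes no measurable difference. The other new comparison, a 35-fold lower number from compound 2 to compound 3 (1.55 log units; beyond the scatter), is large and places compound 2, with its furan-2-yl group, well apart from both thiophene compounds, so among these three compounds the large differences appear only when furan-2-yl is compared with a thiophene. Nothing available explains why the furan-2-yl compound stands so far from the two thiophene compounds.

The compounds shown leave open whether furan-3-yl on the same carbonyl carbon would give a number close to that of compound 2 or close to those of compound 1 and compound 3, a comparison that would show whether the furan ring itself or its furan-2-yl form goes with the large step. They also leave open how a phenyl or pyridin-3-yl group would compare at this place, with the rest of the molecule kept the same.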